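Working notes: metabolic stability across compounds 1 to 4

This account rests on a few compounds, and the source may have more. Where it says the series, first, only, none or still open, it means among the compounds named here.

Measured so far:
- compound 1 `NS(=O)(=O)c1cc(-c2nnc(CN3CCN(c4ccc(Cl)cc4)CC3)o2)c(Cl)cc1SCc1ccccc1` gives 0.455 h
- compound 2 `Cc1ccc(C)c(N2CCN(Cc3nnc(-c4cc(S(N)(=O)=O)c(SCc5ccccc5)cc4Cl)o3)CC2)c1` gives 0.208 h
- compound 3 `NC(=O)c1cn(Cc2nnc(-c3cc(S(N)(=O)=O)c(SCc4ccccc4)cc3Cl)o2)nn1` gives 0.435 h

All three numbers come from an ADME assay on microsomes from liver (Homo sapiens) for metabolic stability, read by LC-MS, using NADPH, tested at 5 uM; on this read-out lower numbers stand for a shorter-lived compound and higher numbers for a longer-lived compound. Compound 3 stands second highest of the three: its value and that of compound 1 lie within the scatter of one another, while compound 2 sits beyond the scatter below it. Going by the values given here, the only measured single-point step, a 2.2-fold lower number from compound 1 to compound 2 (0.34 log units; beyond the scatter), concerns 2,5-dimethylphenyl in place of 4-chlorophenyl on an amine nitrogen in a ring, a position untouched here.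

Compound 4 `NS(=O)(=O)c1cc(-c2nnc(/C=C/c3ccc(Cl)cc3)o2)c(Cl)cc1SCc1ccccc1` differs from compound 3 in 2-(4-chlorophenyl)ethenyl in place of (4-carbamoyl-1H-1,2,3-triazol-1-yl)methyl on an aromatic carbon. Among the compounds with values here, no measured step bears on that exchange, so in this assay no step beyond the scatter is expected in either direction. Compound 4 is estimated at 0.42 h, with a range from 0.2 h to 0.9 h. The step this estimate implies, a 1.0-fold lower number from compound 3 to compound 4 (0.02 log units; within the scatter), is expected to stay within the scatter.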

Compound 4, half-life: 0.207 h
The estimate for compound 4 lay 2.0-fold (0.31 log units) above the measured number; the measured number falls inside the stated range.
By their numbers in this assay, from the lowest: compounds 4 and 2 (each within the scatter of the next); then compounds 3 and 1 (each within the scatter of the next).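

In this assay, the exchange of (4-carbamoyl-1H-1,2,3-triazol-1-yl)methyl for 2-(4-chlorophenyl)ethenyl on this aromatic carbon gives a 2.1-fold lower number from compound 3 to compound 4 (0.32 log units; beyond the scatter) as a modest step. The earlier step concerned only the aryl group on the ring amine nitrogen, whereas this one shows that the read-out also responds to a change at this position. No measured evidence accounts for this step.

Going by these compounds alone, the single exchange does not separate the contributions of the leaving and entering groups. From the compounds shown here alone, how a carboxylic acid in place of the carbamoyl or a plain phenyl in place of the 4-chlorophenyl would read remains open.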